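From Piperazinylmethyl to Pyrrolidinylcarbonyl on a Ring Carbon

This account rests on a few compounds, and the source may have more. Where it says the series, first, only, none or still open, it means among the compounds named here.

Compound 1 `CC(C)=CCC[C@]1(C)/C=C/[C@@H](OC(=O)C=C(C)C)[C@](C)(O)/C=C/C(=O)/C(CN2CCN(C)CC2)=C\C1` is one of three compounds tested in a functional assay on SMMC-7721 cells (Homo sapiens) for antiproliferative activity, read by MTT assay, with a stated time of 48 h; on this read-out lower numbers stand for stronger inhibition and higher numbers for weaker inhibition. Compound 1 gives 2940 nM, the lowest of the three numbers. Compound 3 `CC(C)=CCC[C@](C)(/C=C/[C@@H](OC(=O)C=C(C)C)[C@](C)(O)/C=C/C(=O)/C=C/N1CCN(C)CC1)CC=O` gives 3090 nM in this assay, a number within the scatter of compound 1, so the two cannot be set apart. Compound 2 `CC(C)=CCC[C@]1(C)/C=C/[C@@H](OC(=O)C=C(C)C)[C@](C)(O)/C=C/C(=O)/C(C[Si](c2ccccc2)(c2ccccc2)C(C)(C)C)=C\C1` gives 38000 nM in this assay, a number far above that of compound 1 and well beyond the scatter.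

Compound 4 `CC(C)=CCC[C@]1(C)/C=C/[C@@H](OC(=O)C=C(C)C)[C@](C)(O)/C=C/C(=O)/C(C(=O)N2CCCC2)=C\C1` has not yet been measured. It differs from compound 1 in one place: (pyrrolidin-1-yl)carbonyl in place of (4-methylpiperazin-1-yl)methyl on a double-bonded ring carbon. Among the measured compounds shown here, no pair of measured compounds isolates this exact change, so its effect must be guessed. For the measured compounds named here, the one measured compound that lacks the (4-methylpiperazin-1-yl)methyl group, compound 2, gives 38000 nM in this assay. Compound 4 is therefore expected to give about 10000 nM, with a range from 3000 nM to 35000 nM. The step of a 3.4-fold higher number from compound 1 to compound 4 (0.53 log units; beyond the scatter) is expected to be a weakening beyond the scatter, because compound 2 gives 38000 nM.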

Compound 4, half-maximal inhibitory concentration: 14900 nM
Compound 4: the middle estimate sits 1.5-fold (0.17 log units) below what was measured, and the stated range covers the measured number.
By their numbers in this assay, from the lowest: compounds 1 and 3 (each within the scatter of the next); then compound 4; then compound 2.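

In this assay, placing (pyrrolidin-1-yl)carbonyl instead of (4-methylpiperazin-1-yl)methyl on this double-bonded ring carbon gives a 5.1-fold higher number from compound 1 to compound 4 (0.70 log units; beyond the scatter), a weakening. Among the compounds shown here, this is the first direct one-place reading at this position, and it shows that the group held there can change the result while the rest of the molecule stays the same. The swap alters the ring, the number of ring nitrogens and the carbonyl together, and no measurement shown explains the weakening.

The compounds shown leave open which of these parts accounts for the step. A (pyrrolidin-1-yl)methyl group or a (4-methylpiperazin-1-yl)carbonyl group at this carbon would help separate the effect of the carbonyl from that of the ring.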